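A few compounds are considered here, and "the series" means these few. Any claim that something is new, unique, unknown or untested is made for them only; others in the source may bear on it.

Compound 1 `CC1(C)[C@H]2CC[C@]1(C)N(Cc1cn(-c3ccccc3O)nn1)C(=O)C2`: 540 nM
Compound 2 `COc1ccc(-n2cc(CN3C(=O)C[C@@H]4CC[C@@]3(C)C4(C)C)nn2)cc1`: 70 nM
Compound 3 `Cc1ccc(-n2cc(CN3C(=O)C[C@@H]4CC[C@@]3(C)C4(C)C)nn2)cc1`: 50 nM

These three compounds share one core and differ only in the aryl group on the aromatic nitrogen. In a functional assay on LoVo cells (Homo sapiens) for inhibition, read by MTT assay, with a stated time of 24 h (on this read-out lower numbers stand for stronger inhibition and higher numbers for weaker inhibition), compound 1 gives the highest number of the three, so it is the weakest inhibitor of this small set. Compound 4 `CC1(C)[C@H]2CC[C@]1(C)N(Cc1cn(-c3ccccc3Br)nn1)C(=O)C2` differs from compound 1 in one place: bromo in place of hydroxy on an aromatic carbon. For the measured compounds named here, no measured step exchanges the hydroxy for another group on that aromatic carbon. The nearest evidence is a 7.7-fold lower number from compound 1 to compound 2 (0.89 log units; beyond the scatter) and an 11-fold lower number from compound 1 to compound 3 (1.03 log units; beyond the scatter), both of which remove the 2-hydroxyphenyl altogether and lead to a much lower number. From the compounds shown here alone, on that basis a drop is expected for compound 4 as well, though a more cautious one, as the 2-bromophenyl itself is untested. The estimate for compound 4 is 200 nM, with a range from 60 nM to 700 nM, which corresponds to an expected step of a 2.7-fold lower number from compound 1 to compound 4 (0.43 log units; beyond the scatter).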

Compound 4, half-maximal inhibitory concentration: 60 nM
The estimate for compound 4 lay 3.3-fold (0.52 log units) above the measured number; the range from low to high includes it.
By their numbers in this assay, from the lowest: compounds 3, 4 and 2 (each within the scatter of the next); then compound 1.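

In this assay, for the compounds shown here, the earlier steps changed both the group and its place on the ring, whereas this change keeps the place and swaps only hydroxy for bromo, giving a 9.0-fold lower number from compound 1 to compound 4 (0.95 log units; beyond the scatter). The lower number therefore does not depend on moving the group to the 4-position, as compound 4 matches the 4-substituted compounds, with a 1.2-fold higher number from compound 3 to compound 4 (0.08 log units; within the scatter) and a 1.2-fold lower number from compound 2 to compound 4 (0.07 log units; within the scatter). Nothing measured here explains the gap between hydroxy and bromo. Still open, from the compounds shown here alone, is how an amine or a carboxylic acid on this aromatic carbon would read, and so whether hydroxy alone stands out.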